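The source may hold more compounds than are shown below. What is called first, only, known or untested is meant among the compounds shown, and "the series" means these compounds.

Measured compounds in a functional assay on MCF7 cells (Homo sapiens) for cytotoxicity, read by MTT assay, with a stated time of 48 h; a lower number here means a stronger inhibitor, a higher number a weaker inhibitor:
- compound 1 `Cc1c(CO)c(CO)c2n1[C@@H](c1ccccc1)SC2`: compound 1 gives 1900 nM
- compound 2 `Cc1c(CO)cc2n1CSC2`: compound 2 gives 156000 nM
- compound 3 `Cc1c(CO)c(CO)c2n1CSC2`: compound 3 gives 38100 nM

Compound 3 stands second highest of the three numbers in this assay; compound 2 is nearest, compound 1 furthest. The step from compound 2 to compound 3 is a 4.1-fold lower number from compound 2 to compound 3 (0.61 log units; beyond the scatter), for hydroxymethyl in place of hydrogen on an aromatic carbon. The step from compound 1 to compound 3 is a 20-fold higher number from compound 1 to compound 3 (1.30 log units; beyond the scatter), for hydrogen in place of phenyl on a saturated ring carbon.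

Compound 4 `Cc1c(CO)c(CO)c2n1[C@H](c1ccccc1)SC2` is not yet measured. It differs from compound 3 by phenyl in place of hydrogen on a saturated ring carbon. Within the data shown here, this reverses the change seen from compound 1 to compound 3, though compound 4 carries the phenyl in the other configuration at that carbon, and no step between the two configurations is known here. Among the measured compounds shown here, only the step from compound 1 to compound 3 bears on it, and it was large. A large step downward in this assay is therefore expected, an 11-fold lower number from compound 3 to compound 4 (1.04 log units; beyond the scatter), with the width of the range reflecting the unknown effect of configuration. Compound 4 is expected to give about 3500 nM, between 900 nM and 20000 nM.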

Compound 4, half-maximal inhibitory concentration: 540 nM
Compound 4: middle estimate off by 6.5-fold (0.81 log units), on the high side; the measured number lies below the stated range.
By their numbers in this assay, from the lowest: compound 4; then compound 1; then compound 3; then compound 2.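

In this assay, phenyl in place of hydrogen on this saturated ring carbon also lowers the number in the second configuration, giving a 71-fold lower number from compound 3 to compound 4 (1.85 log units; beyond the scatter). The earlier compounds shown here showed this carbon's phenyl in one configuration only; configuration at the carbon now proves to matter beyond the scatter, with a 3.5-fold lower number from compound 1 to compound 4 (0.55 log units; beyond the scatter), and the S configuration as drawn gives the lower number of the pair. That gap can be tied to the stereocentre alone, given: the fact that compounds 1 and 4 differ only in the configuration as drawn

As far as these compounds go, whether the gain belongs to phenyl specifically remains open, since a methyl, a benzyl or a pyridyl at this carbon, or a chlorine or methoxy on the phenyl, is not covered by these compounds. Also open, from the compounds shown here alone, is whether the hydroxymethyl step on the aromatic carbon, seen only without phenyl, carries over when phenyl is present.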